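The compounds below may be only part of what the source reports. "The series", "measured", "known", "first", "only" and "open" are said of these compounds alone.

Measured in a functional assay on HL-60 cells (Homo sapiens) for cytotoxicity, read by WST assay, with a stated time of 48 h; a higher number here means a weaker inhibitor, a lower number a stronger inhibitor:
compound 1 `COc1ccc(/C=C/C[C@H]2C[C@H]([C@H](O)c3ccc(OC)c(OC)c3)CO[C@@H]2c2ccc(OC)c(OC)c2)cc1OC`, 23500 nM
compound 2 `O[C@@H](c1ccccc1)[C@H]1CO[C@H](c2ccccc2)[C@@H](C/C=C/C2CCCC2)C1`, 9060 nM
compound 3 `COc1ccc(/C=C/C[C@H]2C[C@@H]([C@@H](O)c3ccc(OC)c(OC)c3)CO[C@@H]2c2ccc(OC)c(OC)c2)cc1OC`, 34700 nM

Compound 2 gives the lowest number of the three; compound 1 and compound 3 both sit higher by more than the usual scatter. Among the measured compounds shown here, the only single-place step among the measured compounds is the one between compound 1 and compound 3, a 1.5-fold higher number from compound 1 to compound 3 (0.17 log units; within the scatter), and it rests on (the fact that compounds 1 and 3 differ only in the configuration as drawn), so it says nothing about a change of substituent.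

Compound 4 `O[C@@H](c1ccccc1)[C@H]1CO[C@H](c2ccccc2)[C@@H](C/C=C/c2ccncc2)C1` is the next member, reached from compound 2 by pyridin-4-yl in place of cyclopentyl on a double-bonded chain carbon bound to a double-bonded chain carbon. For the measured compounds named here, no measured step bears on this change: compound 1 and compound 3 differ from compound 2 in several places at once, so no single-change comparison can be drawn from them. Without a guide, the expected step in this assay is none beyond the scatter, a 1.3-fold higher number from compound 2 to compound 4 (0.12 log units; within the scatter). Compound 4 is therefore estimated at 12000 nM, with a range from 4000 nM to 40000 nM.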

Compound 4, half-maximal inhibitory concentration: > 100000 nM
Compound 4 gave a limit, no number (the forecaster's own chance of this, stated with the estimate: 5%); middle value at least 8.3-fold (0.92 log units) away from the limit.
By their numbers in this assay, from the lowest: compound 2; then compounds 1 and 3 (each within the scatter of the next). At a limit, above all of these: compound 4.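

In this assay the group on a double-bonded chain carbon bound to a double-bonded chain carbon clearly matters, since pyridin-4-yl in place of cyclopentyl gives an at least 11-fold higher number from compound 2 to compound 4 (1.04 log units; beyond the scatter) at this place. Among the compounds shown here, the earlier compounds offered only a change of configuration as drawn, a 1.5-fold higher number from compound 1 to compound 3 (0.17 log units; within the scatter) within the scatter, so this is the first single-place change of substituent and the first single-place step beyond the scatter. Compound 4 stands at a limit rather than a number, so the size of the step is only a bound: the limit of > 100000 nM in this assay, at which 1 of the 4 values shown sits.

The compounds shown do not separate the ring nitrogen from the change of a non-aromatic ring to an aromatic one, and phenyl or cyclohexyl at this place would bear on that. On these data alone, whether the same change has a comparable effect on the core of compound 1 also stays open.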